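This account rests on a few compounds, and the source may have more. Where it says the series, first, only, none or still open, it means among the compounds named here.

Working notes on the series. Compound 1 `CCC(C)OC(=O)NS(=O)(=O)c1sc(CC(C)C)cc1-c1cccc(Cn2ccnc2)c1` gives 0.783 h in an ADME assay on microsomes from liver (Mus musculus) for metabolic stability, read by LC-MS, using NADPH, tested at 1 uM; a lower number here means that the compound disappears faster, a higher number that the compound lasts longer. Compound 2 `CC(C)COC(=O)NS(=O)(=O)c1sc(CC(C)C)cc1-c1cccc(Cn2ccnc2)c1` gives 0.633 h in this assay, and compound 3 `CC(C)CCOC(=O)NS(=O)(=O)c1sc(CC(C)C)cc1-c1cccc(Cn2ccnc2)c1` gives 0.217 h in this assay. Compound 3 stands lowest of the three numbers: the step of a 3.6-fold lower number from compound 1 to compound 3 (0.56 log units; beyond the scatter) and the step of a 2.9-fold lower number from compound 2 to compound 3 (0.46 log units; beyond the scatter) both lie beyond the scatter, while the step of a 1.2-fold lower number from compound 1 to compound 2 (0.09 log units; within the scatter) stays within it, so compound 1 and compound 2 cannot be ordered against each other.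

Compound 4 `CC(C)Cc1cc(-c2cccc(Cn3ccnc3)c2)c(S(=O)(=O)NC(=O)C2CC2)s1` is not yet measured. It differs from compound 3 by cyclopropyl in place of isopentyloxy on a carbonyl carbon. Within the data shown here, none of the measured steps covers a change of this kind: all three move only within the chain on the oxygen next to a carbonyl group, and the oxygen itself stays. What they do show is that the isopentyl chain carries the lowest number, since compound 3 sits at 0.217 h with the steps of a 3.6-fold lower number from compound 1 to compound 3 (0.56 log units; beyond the scatter) and a 2.9-fold lower number from compound 2 to compound 3 (0.46 log units; beyond the scatter) above it. On that basis the step of a 2.3-fold higher number from compound 3 to compound 4 (0.36 log units; beyond the scatter) is expected to run upward by a modest amount, with wide uncertainty because compound 3 at 0.217 h is the only anchor for the new group. For compound 4 the estimate is 0.5 h, with a range from 0.2 h to 1.3 h.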

Compound 4, half-life: 1.1 h
Compound 4: middle estimate off by 2.2-fold (0.34 log units), on the low side; low and high end bracket the measured number.
By their numbers in this assay, from the lowest: compound 3; then compounds 2, 1 and 4 (each within the scatter of the next).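

At this position, on a carbonyl carbon whose other neighbour is the amide-type nitrogen, the oxygen-linked chain can be replaced outright: in this assay, cyclopropyl, with 3 heavy atoms and no oxygen against 6 heavy atoms for isopentyloxy, gives a 5.1-fold higher number from compound 3 to compound 4 (0.70 log units; beyond the scatter). Against the two shorter chains the same exchange stays inside the scatter, with a 1.7-fold higher number from compound 2 to compound 4 (0.24 log units; within the scatter) and a 1.4-fold higher number from compound 1 to compound 4 (0.15 log units; within the scatter), so compound 4 cannot be ordered against compound 1 or compound 2, and among these four compounds only compound 3 stands apart from the others. Nothing available for this series accounts for the rise from the isopentyloxy compound, and the numbers themselves give no explanation for it.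

From the compounds shown here alone, whether the ring matters, or any small carbon group without oxygen on this carbonyl carbon would serve as well, stays open, and a methyl, a straight propyl chain or a cyclobutyl ring there would separate these cases. Also open, going by these compounds, is how an amine such as dimethylamino at the same place would compare with both cyclopropyl and the oxygen-linked chains.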